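This account rests on a few compounds, and the source may have more. Where it says the series, first, only, none or still open, it means among the compounds named here.

Three compounds have so far been measured in an assay on cells for inhibition of Amine oxidase [flavin-containing] B (Homo sapiens), read by fluorescence and Amplex Red, using microsomes, with a stated time of 15 min; on this read-out lower numbers stand for stronger inhibition and higher numbers for weaker inhibition:

Compound 1 `Cc1cccc(NC(=O)c2cc3cc(C)ccc3oc2=O)c1`: 7.52 nM
Compound 2 `Cc1ccc2occ(C(=O)Nc3cccc(Cl)c3)c(=O)c2c1`: 4.2 nM
Compound 3 `COc1ccc2occ(C(=O)Nc3cccc(Cl)c3)c(=O)c2c1`: 3.94 nM

Compound 3 shows the lowest of the three numbers, but its gap to compound 2 and its gap to compound 1 both lie within the scatter of repeated measurements, so the three compounds stand level rather than in any order. Within the data shown here, the only measured step that changes a single place, a 1.1-fold lower number from compound 2 to compound 3 (0.03 log units; within the scatter), puts methoxy in place of methyl on an aromatic carbon and leaves the number where it was.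

Compound 4 `COc1ccc2occ(C(=O)Nc3ccc(Cl)cc3)c(=O)c2c1` has not yet been measured. It differs from compound 3 in one place: 4-chlorophenyl in place of 3-chlorophenyl on an amide-type nitrogen. Among the measured compounds shown here, no measured step bears on this change. For the measured compounds named here, the single step on record concerns a different group at a different place, and no measured pair differs only in where the chlorine sits on the chlorophenyl group. The shown numbers therefore give no ground for expecting a shift in either direction, and the expected step of a 1.5-fold higher number from compound 3 to compound 4 (0.18 log units; within the scatter) is set near zero, with a wide range to cover what is not known. Compound 4 is thus estimated to give 6 nM, within a range from 1.5 nM to 25 nM.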

Compound 4, half-maximal inhibitory concentration: 10.3 nM
Estimate against measurement, compound 4: 1.7-fold (0.23 log units) below; low and high end bracket the measured number.
By their numbers in this assay, from the lowest: compounds 3, 2, 1 and 4 (each within the scatter of the next, the first and the last beyond it).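

In this assay, 4-chlorophenyl in place of 3-chlorophenyl on the amide-type nitrogen gives a 2.6-fold higher number from compound 3 to compound 4 (0.42 log units; beyond the scatter), which means modestly weaker inhibition. Among these compounds, the two groups hold the same atoms and differ only in where the chlorine sits, so this place on the molecule responds to a rearrangement alone, whereas the one earlier single-place step, a 1.1-fold lower number from compound 2 to compound 3 (0.03 log units; within the scatter), made at a different place, left the number within the scatter. Nothing at hand explains how the chlorine's location produces this shift.

On these data alone, this is a single pair, so it remains open whether the same exchange of chlorophenyl groups would raise the number to a similar extent in compound 2, which carries methyl where compound 3 carries methoxy. As far as these compounds go, it is also open how the number would respond if a different group, such as a fluorine, a nitrile, an amine or a carboxylic acid, took the place of the chlorine in compound 3 or compound 4.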